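A few compounds are considered here, and "the series" means these few. Any claim that something is new, unique, unknown or untested is made for them only; others in the source may bear on it.

Among the measured compounds shown here, compound 2 `O=C(C1CC1)N1CCN(c2nc(=O)c3cc(C(F)(F)F)cc([N+](=O)[O-])c3s2)CC1` gives 52.9 ug/mL in a physicochemical assay for solubility, read by HPLC (a lower number here means a less soluble compound, a higher number a more soluble compound), the higher of the two numbers measured so far; compound 1 `CC(C)(C)C(=O)N1CCN(c2nc(=O)c3cc(C(F)(F)F)cc([N+](=O)[O-])c3s2)CC1` gives 5.87 ug/mL in the same assay. For the measured compounds named here, the one step already measured, a 9.0-fold higher number from compound 1 to compound 2 (0.95 log units; beyond the scatter), shows that a change of the group on the carbonyl carbon can move this read-out well beyond the scatter. Compound 3 `O=C(C1CCCCC1)N1CCN(c2nc(=O)c3cc(C(F)(F)F)cc([N+](=O)[O-])c3s2)CC1` differs from compound 2 by cyclohexyl in place of cyclopropyl on a carbonyl carbon, a bulkier group in that same place. Because compound 1 with its tert-butyl group sits at 5.87 ug/mL, the expected step is an 11-fold lower number from compound 2 to compound 3 (1.02 log units; beyond the scatter), downward. Compound 3 is therefore estimated at 5 ug/mL, within a range from 1.5 ug/mL to 20 ug/mL.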

Compound 3, solubility: 3.24 ug/mL
Compound 3: middle estimate off by 1.5-fold (0.19 log units), on the high side; the range from low to high includes it.
By their numbers in this assay, from the lowest: compounds 3 and 1 (each within the scatter of the next); then compound 2.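

Cyclohexyl on the carbonyl carbon gives a 16-fold lower number from compound 2 to compound 3 (1.21 log units; beyond the scatter), so the high number of compound 2 is not shared by every carbon ring at this place. Replacing tert-butyl with cyclohexyl gives a 1.8-fold lower number from compound 1 to compound 3 (0.26 log units; within the scatter), so this assay does not separate these two groups. Nothing measured here explains why both stand so far from cyclopropyl. From the compounds shown here alone, whether cyclobutyl or isopropyl on that carbonyl carbon would stay close to compound 2 or to compound 3 remains open. So does the outcome for a tetrahydropyranyl ring, which carries an oxygen atom.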